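The source may report more compounds than this note shows. Statements on the series, on what has been measured and on what is new or still open speak of the compounds shown alone.

Working notes on the series. Compound 1 `COc1ccc(Cn2cnc3c(N(C)c4ccc(OC)cc4)ncnc32)cc1` in a functional assay on SH-SY5Y cells (Homo sapiens) for antiproliferative activity, read by MTT assay, with a stated time of 48 h (a higher number here means a weaker inhibitor of growth, a lower number a stronger inhibitor of growth), gives 27000 nM. Compound 2 `COc1ccc(N(C)c2ncnc3c2ncn3Cc2ccc(OC)c(OC)c2)cc1` in this assay gives 430 nM. The step of a 63-fold lower number from compound 1 to compound 2 (1.80 log units; beyond the scatter) goes with the change (methoxy in place of hydrogen on an aromatic carbon). Compound 3 `COc1ccc(N(C)c2nc(Cl)nc3c2ncn3Cc2cc(OC)cc(OC)c2)cc1` carries a core that is not that of compound 1; the difference between the two cores is not broken down here. In this assay compound 3 returns only a limit, > 100000 nM. That limit is the limit of > 100000 nM in this assay, at which 1 of the 3 values shown sits. Compound 4 `COc1ccc(N(C)c2nc(Cl)nc3c2ncn3Cc2cc(OC)c(OC)c(OC)c2)cc1` awaits measurement in this assay; it arises from compound 3 by methoxy in place of hydrogen on an aromatic carbon, the same kind of change as from compound 1 to compound 2, but not the same: in compound 4 the entering group sits ortho to two methoxy groups and para to a large group, whereas in compound 2 it sits ortho to a methoxy group and meta to a large group. Beside the measured step from compound 1 to compound 2, a smaller move an at least 1.6-fold lower number from compound 3 to compound 4 (0.22 log units; that floor lies within the scatter) is expected, resting on compound 3 sitting at a limit and on the changed surroundings of the place. For compound 4 in this assay the estimate is 60000 nM, from 10000 nM to 200000 nM.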

Compound 4, concentration for 50% growth inhibition: 3000 nM
Beside the measured number, compound 4's estimate is 20-fold (1.30 log units) above it, outside the stated range (below it).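

In this assay, methoxy in place of hydrogen on an aromatic carbon goes with a large drop in the number on the core of compound 3 as well (an at least 33-fold lower number from compound 3 to compound 4 (1.52 log units; beyond the scatter)), so across these two pairs the change carries over in direction, with both steps beyond the scatter. Whether its size carries over stays unsettled, and the two pairs also differ in the surroundings of the place, with the entering methoxy in compound 4 ortho to two methoxy groups and para to a large group: the same change on two cores in this assay, a 63-fold lower number (1.80 log units; beyond the scatter) from compound 1 to compound 2 and an at least 33-fold lower number (1.52 log units; beyond the scatter) from compound 3 to compound 4; the limit leaves it open whether they differ. Compound 3 returns a limit and not a number, so its step has only a floor, and two pairs on two cores make no rule for the series: the limit of > 100000 nM in this assay, at which 1 of the 4 values shown sits.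

The compounds shown leave open whether a hydroxyl, an ethoxy or an amine at the same place would go with a step of this kind. They also leave open how much of each step belongs to the core, since the difference between the two cores is not broken down here.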